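Removing the trifluoromethyl group: compound 3 to compound 4

The source may report more compounds than this note shows. Statements on the series, on what has been measured and on what is new or still open speak of the compounds shown alone.

In a functional assay on MCF7 cells (Homo sapiens) for cytotoxicity, read by MTT assay, with a stated time of 72 h (a higher number here means a weaker inhibitor, a lower number a stronger inhibitor), compound 3 `O=C(Nc1ccc(Oc2ccnc3[nH]ccc23)cc1)c1cc(-c2ccc(C(F)(F)F)cc2)ncn1` gives 6240 nM. Compound 1 `COc1ccc(-c2cc(C(=O)Nc3ccc(Oc4ccnc5[nH]ccc45)cc3)ncn2)cc1` gives 4450 nM and compound 2 `O=C(Nc1ccc(Oc2ccnc3[nH]ccc23)cc1)c1cc(-c2ccc(Cl)cc2)ncn1` gives 7770 nM in this assay; the steps of a 1.4-fold higher number from compound 1 to compound 3 (0.15 log units; within the scatter) and a 1.2-fold lower number from compound 2 to compound 3 (0.10 log units; within the scatter) both lie within the scatter, so the three values sit together and no separation among them can be read. Compound 4 `O=C(Nc1ccc(Oc2ccnc3[nH]ccc23)cc1)c1cc(-c2ccccc2)ncn1` differs from compound 3 by hydrogen in place of trifluoromethyl on an aromatic carbon. The same position has so far carried methoxy, chloro and trifluoromethyl, and the steps among those three, a 1.7-fold higher number from compound 1 to compound 2 (0.24 log units; within the scatter) included, all stayed within the scatter. None of them involves hydrogen, so the step to an unsubstituted phenyl is not directly covered by the measured pairs. With no change at this position having moved this assay beyond the scatter, the expectation for compound 4 is a step of a 1.0-fold lower number from compound 3 to compound 4 (0.02 log units; within the scatter), none beyond the scatter. Compound 4 is therefore estimated at 6000 nM in this assay, within 2500 nM to 14000 nM.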

Compound 4, half-maximal inhibitory concentration: 20 nM
Beside the measured number, compound 4's estimate is 300-fold (2.48 log units) above it; measured number below the stated range.
By their numbers in this assay, from the lowest: compound 4; then compounds 1, 3 and 2 (each within the scatter of the next).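

In this assay, this position turns out to be far from indifferent: a 310-fold lower number from compound 3 to compound 4 (2.49 log units; beyond the scatter), a 390-fold lower number from compound 2 to compound 4 (2.59 log units; beyond the scatter) and a 220-fold lower number from compound 1 to compound 4 (2.35 log units; beyond the scatter), each a large step beyond the scatter. Among these four compounds the split lies between hydrogen and any of the three substituents, with methoxy, chloro and trifluoromethyl all on the same side and no compound going against it, which makes compound 4 the most potent of the four. Nothing available here accounts for so large a gap.

Going by these compounds, it remains open whether fluoro, methyl or an amine at this position would stay with compound 4 or fall in with compounds 1, 2 and 3. Also open, on these data alone, is whether the same groups on other carbons of this phenyl ring would give a step of this size.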